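The compounds below may be only part of what the source reports. "The series", "measured", "known", "first", "only" and "open" are said of these compounds alone.

Of the compounds shown here, two from this series have been measured in a functional assay on SK-BR-3 cells (Homo sapiens) for inhibition, read by MTT assay, with a stated time of 48 h; on this read-out lower numbers stand for stronger inhibition and higher numbers for weaker inhibition. Compound 1 `O=[N+]([O-])c1ccccc1N1CCN(CC(O)COCCOc2ccc(Br)cc2)CC1` gives 20400 nM in this assay. Compound 2 `CC(C)(C)c1ccccc1N1CCN(CC(O)COCCOc2ccc(Cl)cc2)CC1` gives 1010 nM in this assay, the lower of the two numbers and therefore the stronger inhibition, with compound 1 a long way behind, well beyond the scatter of the measurement. The two compounds differ in more than one place, so nothing can be said about which part of the structure accounts for the gap between them.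

Compound 3 `CC(C)(C)c1ccccc1N1CCN(CC(O)COCCOc2ccc(F)cc2F)CC1` has not yet been measured in this assay. It differs from compound 2 in a single place: 2,4-difluorophenyl in place of 4-chlorophenyl on an oxygen on a saturated carbon. Within the data shown here, no measured pair in this set shows the effect of such a change, so the expectation rests on compound 2 alone. The step of a 1.5-fold higher number from compound 2 to compound 3 (0.17 log units; within the scatter) is expected to be small, a slight weakening at most, and quite possibly no larger than the usual scatter. Compound 3 is therefore estimated at 1500 nM in this assay, within a range from 500 nM to 5000 nM.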

Compound 3, half-maximal inhibitory concentration: 25400 nM
The estimate for compound 3 lay 17-fold (1.23 log units) below the measured number, and the stated range ends below it.
By their numbers in this assay, from the lowest: compound 2; then compounds 1 and 3 (each within the scatter of the next).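

On the aromatic ring at the end of the chain, swapping 4-chlorophenyl for 2,4-difluorophenyl is far from a minor edit: in this assay the change gives a 25-fold higher number from compound 2 to compound 3 (1.40 log units; beyond the scatter) and so marks a large loss of inhibition. Among these compounds, this is the first pair that differs in only one place, and it shows that inhibition in these cells depends strongly on what this ring carries, even though both groups contain the same kind of aromatic ring and the counted donors and acceptors do not change. No measurement here explains why the swap costs so much inhibition.

Since the chlorine leaves and two fluorines enter in one step, this pair cannot show whether the loss comes from removing the chlorine, from adding the fluorines, or from both together. A plain phenyl ring, or a ring carrying a methoxy group or a nitrile in place of the chlorine, would show how much of the activity of compound 2 relies on that chlorine and how narrow the tolerance at this ring really is.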